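Methoxy on the benzyl group of compound 3

The source may hold more compounds than are shown below. What is called first, only, known or untested is meant among the compounds shown, and "the series" means these compounds.

Compound 1 `COc1ccc2nccc(C3CN(C4CCN(Cc5cc6ccccc6n5C)CC4)C(=O)O3)c2c1` gives 3160 nM in an in vitro functional assay on RBL cells for antagonist activity at C-C chemokine receptor type 8 (Homo sapiens), read by FLIPR and calcium flux; on this read-out higher numbers stand for weaker inhibition and lower numbers for stronger inhibition. Compound 2 `COc1ccc2nccc(C3CN(C4CCN(Cc5cc6ccccc6o5)CC4)C(=O)O3)c2c1` gives 1260 nM in this assay, and compound 3 `COc1ccc2nccc(C3CN(C4CCN(Cc5ccccc5)CC4)C(=O)O3)c2c1` gives 12600 nM. Compound 3 stands at the highest number of the three: the step of a 4.0-fold higher number from compound 1 to compound 3 (0.60 log units; beyond the scatter) and the step of a 10-fold higher number from compound 2 to compound 3 (1.00 log units; beyond the scatter) both run upward, while a 2.5-fold lower number from compound 1 to compound 2 (0.40 log units; beyond the scatter) runs the other way.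

Compound 4 `COc1ccc(CN2CCC(N3CC(c4ccnc5ccc(OC)cc45)OC3=O)CC2)cc1` is compound 3 with methoxy in place of hydrogen on an aromatic carbon; the change sits on an aromatic carbon of a six-membered aromatic ring of carbon only, para to a large group, and read one bond further out it is benzyl to 4-methoxybenzyl. Among the compounds with values here, none of the measured steps alters a substituent on this ring; the steps from compound 1 and from compound 2 to compound 3 exchange the whole aryl group and say nothing about a methoxy added to phenyl. Within the data shown here, with no step bearing on it, the expected move in this assay is none beyond the scatter, with a slight lean toward a lower number because compound 3 gives 12600 nM, the highest number of the three. For compound 4 the estimated step of a 1.6-fold lower number from compound 3 to compound 4 (0.20 log units; within the scatter) is expected to be small. Compound 4 is thus estimated at 8000 nM, with a range from 2500 nM to 25000 nM.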

Compound 4, half-maximal inhibitory concentration: 1260 nM
Estimate against measurement, compound 4: 6.3-fold (0.80 log units) above; the whole stated range lies above it.
By their numbers in this assay, from the lowest: compounds 2 and 4 (each within the scatter of the next); then compound 1; then compound 3.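

In this assay, within the data shown here, methoxy in place of hydrogen on an aromatic carbon, para to a large group, gives a 10-fold lower number from compound 3 to compound 4 (1.00 log units; beyond the scatter) and shows that this place on the benzyl group responds to a small substituent, something the earlier steps could not show, as they exchanged the whole aryl group. With 4-methoxyphenyl on the chain carbon, the series shows no change at the digits printed from compound 2 to compound 4 (within the scatter) against 1-benzofuran-2-yl and a 2.5-fold lower number from compound 1 to compound 4 (0.40 log units; beyond the scatter) against 1-methyl-1H-indol-2-yl, so among these compounds a single substituted phenyl ring matches the first of those groups and improves on the second. Nothing at hand offers an explanation for the size of the methoxy step.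

Whether this step is specific to methoxy stays open, as the compounds shown carry no other substituent on this ring: a hydroxyl, a chlorine, an amine, a carboxylic acid or a longer chain such as ethoxy at the same place would test that. Also open, going by these compounds, is how methoxy would read on the aryl groups of compound 1 and compound 2, since neither group carries a substituent here.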